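Chloro for fluoro on the aryl ring of a triazole

The compounds below may be only part of what the source reports. "The series", "measured", "known", "first", "only" and "open" are said of these compounds alone.

Of the compounds shown here, three sharing one core have been measured in a functional assay on PC-12 cells (Rattus norvegicus) for cytotoxicity, read by MTT assay, with stated times of 2 h and 24 h, tested at 1 uM; on this read-out higher numbers stand for a stronger effect at the one concentration tested and lower numbers for a weaker effect. Compound 1 `Oc1cc(C(F)(F)F)ccc1-c1nc(-c2ccccc2O)n(-c2ccc(F)cc2)n1` gives 67.2%. Compound 2 `Oc1cc(C(F)(F)F)ccc1-c1nc(-c2ccccc2O)n(-c2ccc(Cl)cc2)n1` gives 68%, and compound 3 `Oc1cc(C(F)(F)F)ccc1-c1nc(-c2ccccc2O)n(-c2cccc(F)c2)n1` gives 67.2%. Compound 2 differs from compound 1 by chloro in place of fluoro on an aromatic carbon, a change that made a step of a number 0.8 percentage points higher from compound 1 to compound 2 (within the scatter). Compound 3 differs from compound 1 by 3-fluorophenyl in place of 4-fluorophenyl on an aromatic nitrogen, and the step was no change at the digits printed from compound 1 to compound 3 (within the scatter). Compound 2 and compound 3 are separated by a number 0.8 percentage points lower from compound 2 to compound 3 (within the scatter).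

Compound 4 `Oc1cc(C(F)(F)F)ccc1-c1nc(-c2ccccc2O)n(-c2cccc(Cl)c2)n1` is not yet measured. It differs from compound 3 by chloro in place of fluoro on an aromatic carbon. This is the same kind of change as from compound 1 to compound 2, but around the place the surroundings differ: in compound 1 the exchanged atom sits para to a large group, in compound 3 it sits meta to a large group. Because the earlier step was a number 0.8 percentage points higher from compound 1 to compound 2 (within the scatter), and the two cores themselves sit together in no change at the digits printed from compound 1 to compound 3 (within the scatter), a step of a number 0.8 percentage points higher from compound 3 to compound 4 (within the scatter) is expected for compound 4. On that basis compound 4 is estimated at 68%, with a plausible range from 60% to 76% in this assay.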

Compound 4, a percentage reported as activity, at one concentration (the size of the read-out at that concentration, not a potency): 72.3%
Compound 4: the middle estimate sits 4.3 percentage points below what was measured; the measured number falls inside the stated range.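

With a number 5.1 percentage points higher from compound 3 to compound 4 (within the scatter) chloro in place of fluoro on an aromatic carbon has now been read on two cores in this assay, and the two readings cannot be told apart: the same change on two cores in this assay, a number 0.8 percentage points higher (within the scatter) from compound 1 to compound 2 and a number 5.1 percentage points higher (within the scatter) from compound 3 to compound 4, 4.3 percentage points apart, within the scatter of two such steps. The steps of a number 4.3 percentage points higher from compound 2 to compound 4 (within the scatter) and a number 5.1 percentage points higher from compound 1 to compound 4 (within the scatter) likewise stay inside the scatter, so the four compounds read alike on this measure. This shows that the change carried from the core of compound 1 to the core of compound 3 without a detectable difference, yet it does not show that the change has a real effect of its own on either core, and it says nothing about cores beyond these two.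

The compounds shown carry only fluoro or chloro on the phenyl group on the aromatic nitrogen, so it stays open whether a methoxy group, an amine or a carboxylic acid there would read differently. As far as these compounds go, it also stays open whether the picture would hold at other concentrations than the single one used here.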